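The source may report more compounds than this note shows. Statements on the series, on what has been measured and on what is new or still open speak of the compounds shown alone.

Working notes on a small sulfonamide series. Compound 1 `COc1cc(N(Cc2ccc(Cl)cc2)S(=O)(=O)c2ccc(C)cc2)cc(OC)c1OC` and compound 2 `COc1cc(N(Cc2ccc(F)cc2)S(=O)(=O)c2ccc(C)cc2)cc(OC)c1OC` share one core; compound 3 `Cc1ccc(S(=O)(=O)N(Cc2nc3ccccc3[nH]2)c2ccc(F)cc2)cc1` and compound 4 `Cc1ccc(S(=O)(=O)N(Cc2nc3ccccc3[nH]2)c2ccc(Cl)cc2)cc1` share another, and the difference between the two cores is not broken down here. In a functional assay on PC-3 cells (Homo sapiens) for inhibition, read by MTT assay, with a stated time of 48 h (a lower number here means a stronger inhibitor, a higher number a weaker inhibitor), compound 1 gives 14600 nM, and compound 2 gives 20700 nM. Compound 3 gives 45000 nM, the highest number of the three measured, and its gaps to compound 2 and to compound 1 both lie beyond the scatter.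

Between compound 2 and compound 1 the change is chloro in place of fluoro on an aromatic carbon, and it gives a 1.4-fold lower number from compound 2 to compound 1 (0.15 log units; within the scatter). The same change, on the other core, takes compound 3 to compound 4: chloro in place of fluoro on an aromatic carbon. Both place lines read alike, so this is the same change, made twice in all among the compounds shown.

Going by the values given here, the only precedent is the step from compound 2 to compound 1, which stayed within the scatter, so for compound 4 a step of about a 1.4-fold lower number from compound 3 to compound 4 (0.13 log units; within the scatter) is expected, resting on that single pair. Compound 4 is therefore estimated at 33000 nM, with 15000 nM and 70000 nM as the expected range.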

Compound 4, half-maximal inhibitory concentration: 42200 nM
Estimate against measurement, compound 4: 1.3-fold (0.11 log units) below, and the stated range covers the measured number.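

In this assay, the change from 4-fluorophenyl to 4-chlorophenyl gives a 1.1-fold lower number from compound 3 to compound 4 (0.03 log units; within the scatter), so on this second core, as on the first, chloro in place of fluoro leaves the number within the scatter. The two steps agree, and the change carries from one core to the other without a readable difference: the same change on two cores in this assay, a 1.4-fold lower number (0.15 log units; within the scatter) from compound 2 to compound 1 and a 1.1-fold lower number (0.03 log units; within the scatter) from compound 3 to compound 4, 1.3-fold (0.12 log units) apart, within the scatter of two such steps. Going by these compounds alone, this shows only that the change is silent in two pairs in this one cell assay; it does not show that it would stay silent on a further core, and two steps this small say nothing about why the number holds or how these compounds act on the cells.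

The compounds shown leave open whether a different group on that aromatic carbon, such as bromo, methoxy, an amine or a carboxylic acid, would move the number beyond the scatter. Also open, going by these compounds, is how the number responds to a change elsewhere on either core.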